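Swapping methyl for isopropylcarbonyl on a ring nitrogen

The source may hold more compounds than are shown below. What is called first, only, known or untested is meant among the compounds shown, and "the series" means these compounds.

Compound 1 `COc1cc(/C=C2\CN(C)C/C(=C\c3cc(OC)c(OC)c(OC)c3)C2=O)cc(OC)c1OC`: 26400 nM
Compound 2 `COc1ccc(/C=C2\CN(C)C/C(=C\c3ccc(OC)c(OC)c3)C2=O)cc1OC`: 18200 nM

Going by the values given here, in an ADME assay on L02 cells (Homo sapiens) for cytotoxicity, read by MTT assay, with a stated time of 72 h (on this read-out higher numbers stand for weaker inhibition and lower numbers for stronger inhibition), compound 1 at 26400 nM and compound 2 at 18200 nM lie within the usual scatter of each other, so compound 1 stands level with the only other measured compound. Compound 3 `COc1cc(/C=C2\CN(C(=O)C(C)C)C/C(=C\c3cc(OC)c(OC)c(OC)c3)C2=O)cc(OC)c1OC` keeps the core of compound 1 but carries isopropylcarbonyl in place of methyl on an amine nitrogen in a ring. Among the compounds with values here, no measured pair shows a change of this kind, so any forecast is loose. In this assay, a moderate move to a lower number, meaning stronger inhibition, is expected: a 2.6-fold lower number from compound 1 to compound 3 (0.42 log units; beyond the scatter). Compound 3 is estimated at 10000 nM, with an expected range from 3000 nM to 30000 nM.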

Compound 3, half-maximal inhibitory concentration: 12200 nM
Compound 3: the middle estimate sits 1.2-fold (0.09 log units) below what was measured; the measured number falls inside the stated range.
By their numbers in this assay, from the lowest: compounds 3, 2 and 1 (each within the scatter of the next, the first and the last beyond it).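

In this assay putting isopropylcarbonyl in place of methyl on an amine nitrogen in a ring gives a 2.2-fold lower number from compound 1 to compound 3 (0.34 log units; beyond the scatter) and so a modest gain in inhibition, beyond the scatter. The group on this nitrogen can therefore shift the number, which the first two compounds, both carrying methyl there, could not show. No measurement here explains this step. Going by these compounds, whether acetyl, a longer chain or a free amine on this nitrogen would move the number in the same direction stays open.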